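This account rests on a few compounds, and the source may have more. Where it says the series, first, only, none or still open, it means among the compounds named here.

In an ADME assay on KB cells (Homo sapiens) for cytotoxicity, read by MTT assay, with a stated time of 72 h (a lower number here means a stronger inhibitor, a higher number a weaker inhibitor), compound 1 `COc1ccc(C2=C(c3cc(OC)c(OC)c(OC)c3)C(=O)C(OC(C)=O)C2)cc1OC(C)C` gives > 100 ug/mL, which is a limit of the assay and not a number. Compound 2 `COc1cc(C2=C(c3cc(C)c(OC)c(C)c3)C(OC(C)=O)CC2=O)cc(OC)c1OC` gives > 100 ug/mL, also a limit. Compound 1 therefore sits at the limit of > 100 ug/mL in this assay, at which 2 of the 3 values shown sit. Compound 3 `COc1ccc(C2=C(c3cc(OC)c(OC)c(OC)c3)C(=O)C(O[SiH2]C(C)(C)C)C2)cc1OC(C)C` gives a real number, 7.5 ug/mL. The measured step is an at least 13-fold lower number from compound 1 to compound 3 (1.12 log units; beyond the scatter), a large change made on an oxygen on a saturated carbon. Compound 4 `COc1ccc(C2=C(c3cc(OC)c(OC)c(OC)c3)C(=O)C(OC(C)=O)C2)cc1O` differs elsewhere, with isopropoxy changed to hydroxy: hydrogen in place of isopropyl on an oxygen on an aromatic ring. Among the measured compounds shown here, the step to compound 3 lies at another place, so it shows only that compound 1 can move well away from its limit. A modest and uncertain drop is expected, and the estimated step is an at least 3.3-fold lower number from compound 1 to compound 4 (0.52 log units; beyond the scatter). Compound 4 is expected to give 30 ug/mL, with an estimated range of 3 ug/mL to 100 ug/mL.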

Compound 4, half-maximal inhibitory concentration: 35 ug/mL
The estimate for compound 4 lay 1.2-fold (0.07 log units) below the measured number, and the stated range covers the measured number.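

In this assay, the oxygen on the aromatic ring proves to be a second place where the core of compound 1 responds, since hydrogen in place of isopropyl there gives an at least 2.8-fold lower number from compound 1 to compound 4 (0.45 log units; beyond the scatter). The earlier step showed a change only on an oxygen on a saturated carbon. The true size of this new step stays unknown because compound 1 gives a limit and not a number: the limit of > 100 ug/mL in this assay, at which 2 of the 4 values shown sit.

The compounds shown leave open how a methyl group or a longer chain on this oxygen would read. They also leave open how an amine in place of the hydroxy would read.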